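The source may hold more compounds than are shown below. What is called first, only, known or untested is meant among the compounds shown, and "the series" means these compounds.

In a physicochemical assay for solubility, at pH 6.8 (on this read-out lower numbers stand for lower solubility and higher numbers for higher solubility), compound 1 `Cn1cc(-c2ccncc2/C=C/C(=O)Nc2ccccc2)cn1` gives 26 ug/mL. Compound 2 `Cn1cc(-c2ccncc2/C=C/C(=O)Nc2ccc(CN3CC4CC3CO4)cc2)cn1` reads > 82 ug/mL, which is a limit and not a number. The first measured step is an at least 3.1-fold higher number from compound 1 to compound 2 (0.49 log units; beyond the scatter). Compound 3 `O=C(/C=C/c1cnccc1-c1cnn(C2CC2)c1)Nc1ccc(CN2CC3CC2CO3)cc1` reads > 92 ug/mL, which is also a limit and not a number. The next is a step that the two limits leave unreadable from compound 2 to compound 3, so compound 3 has no exact place on the numbers shown.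

Compound 4 `O=C(/C=C/c1cnccc1-c1cnn(C2CC2)c1)Nc1ccc(CN2CC3CC(C2)O3)cc1` has the same atoms as compound 3, joined differently: a group of 7 heavy atoms (5 carbon, 1 nitrogen, 1 oxygen; one four-membered non-aromatic ring with 1 hetero atom, one six-membered non-aromatic ring with 1 hetero atom) in place of a group of 7 heavy atoms (5 carbon, 1 nitrogen, 1 oxygen; 2 five-membered non-aromatic rings with 1 hetero atom each), on a saturated chain carbon bound to an aromatic carbon. Neither measured step exchanges one such group for another, so neither gives a direct size for this change. The first step concerns adding a group in place of a hydrogen atom, and the second cannot be read. Going by the values given here, with no measured step to suggest otherwise, no change beyond the scatter is expected in this assay. The expected step is a step that the limit leaves unreadable from compound 3 to compound 4. For compound 4, the estimated value is 95 ug/mL, with an expected range from 50 ug/mL to 180 ug/mL.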

Compound 4, solubility: 60 ug/mL
For compound 4 the middle estimate is 1.6-fold (0.20 log units) above the measured one, and the stated range covers the measured number.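

The exchange on a saturated chain carbon bound to an aromatic carbon swaps two groups made of the same atoms, and it comes out as an at least 1.5-fold lower number from compound 3 to compound 4 (0.18 log units; that floor lies within the scatter). In this assay compound 4 gives 60 ug/mL, the only exact number shown for a compound carrying either of these two groups, so the series now has a measured value for this kind of substituent rather than limits alone. Compound 3 stands only at a limit, so the full size of the step cannot be read and no shift beyond the scatter is established: the limit of > 92 ug/mL in this assay, at which 1 of the 4 values shown sits.

The compounds shown leave open whether the same exchange would read alike with methyl instead of cyclopropyl on the aromatic nitrogen. They also leave open how a morpholine or a piperazine at the same place would compare with either group.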